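A few compounds are considered here, and "the series" means these few. Any claim that something is new, unique, unknown or untested is made for them only; others in the source may bear on it.

In a functional assay on MOLT-4 cells (Homo sapiens) for antiproliferative activity, with a stated time of 48 h (a higher number here means a weaker inhibitor, a lower number a stronger inhibitor), compound 1 `C=C(Br)C(=O)Nc1ccc(/C=C/C(=O)c2ccc(C)cc2)cc1` gives 1700 nM, compound 2 `C=C(Br)C(=O)Nc1ccc(/C=C/C(=O)c2ccc(OC)cc2)cc1` gives 1300 nM and compound 3 `C=C(Br)C(=O)Nc1ccc(/C=C/C(=O)c2cccs2)cc1` gives 550 nM. Compound 2 thus sits within the scatter of compound 1, as the step of a 1.3-fold lower number from compound 1 to compound 2 (0.12 log units; within the scatter) shows, while the steps of a 2.4-fold lower number from compound 2 to compound 3 (0.37 log units; beyond the scatter) and a 3.1-fold lower number from compound 1 to compound 3 (0.49 log units; beyond the scatter) are modest. Compound 4 `COc1ccc(C(=O)/C=C/c2ccc(N)cc2)cc1` arises from compound 2 by hydrogen in place of (1-bromoethenyl)carbonyl on a nitrogen on an aromatic ring. All three measured compounds keep this group, so those steps bear only indirectly and leave its loss untested. A higher number is nevertheless expected, well beyond the scatter and larger than any measured step. The estimated step is a 9.2-fold higher number from compound 2 to compound 4 (0.97 log units; beyond the scatter). The estimate for compound 4 is 12000 nM, with an expected range of 3500 nM to 40000 nM.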

Compound 4, half-maximal inhibitory concentration: 19000 nM
For compound 4 the middle estimate is 1.6-fold (0.20 log units) below the measured one; the measured number falls inside the stated range.
By their numbers in this assay, from the lowest: compound 3; then compounds 2 and 1 (each within the scatter of the next); then compound 4.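

In this assay, for the compounds shown here, the loss of (1-bromoethenyl)carbonyl from the nitrogen on the aromatic ring, leaving amino, gives a 15-fold higher number from compound 2 to compound 4 (1.16 log units; beyond the scatter) and outruns every step among the earlier compounds, all of which keep this group. The number therefore depends far more on this group than on the changes seen among compound 1, compound 2 and compound 3. Nothing measured here bears on the cause of this step. Open, on these data alone, is how an acetyl or propenoyl group on the same nitrogen would compare, which would separate the contribution of the bromine and the double bond from that of the amide. Also open, as far as these compounds go, is whether the same loss from compound 3 would give a step of similar size.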